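This account rests on a few compounds, and the source may have more. Where it says the series, first, only, none or still open, it means among the compounds named here.

Of the compounds shown here, two on the shared core have so far been measured in an assay on isolated protein for inhibition of Dihydrofolate reductase (Homo sapiens), read by spectrophotometry, using NADPH, with stated times of 5 s and 6 min, tested at 50 uM; on this read-out higher numbers stand for a stronger effect at the one concentration tested and lower numbers for a weaker effect. Compound 1 `NC1=NC2(CCSCC2)N(OCCCOc2ccc(Cl)c(Cl)c2)C(N)=N1` gives 89.8% in this assay and stands highest of the two numbers, though compound 2 `CC(C)(C)c1ccc(OCCCON2C(N)=NC(N)=NC23CCSCC3)cc1` gives 86.6% and lies within the scatter of it, so the two are not separated. Compound 3 `NC1=NC2(CCSCC2)N(OCCCOc2cccc(Cl)c2)C(N)=N1` is not yet measured; it differs from compound 1 by hydrogen in place of chloro on an aromatic carbon. Going by the values given here, no measured pair covers this change, so the expectation rests on the change alone: a modest loss is expected, a number 9.8 percentage points lower from compound 1 to compound 3 (within the scatter), near the edge of the scatter. Compound 3 is estimated at 80%, with a range from 62% to 92%.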

Compound 3, a percentage reported as inhibition, at one concentration (the size of the read-out at that concentration, not a potency): 88.8%
For compound 3 the middle estimate is 8.8 percentage points below the measured one; the measured number falls inside the stated range.
By their numbers in this assay, from the lowest: compounds 2, 3 and 1 (each within the scatter of the next).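

In this assay, 3,4-dichlorophenyl to 3-chlorophenyl gives a number 1 percentage points lower from compound 1 to compound 3 (within the scatter), so the chloro para to a large group is not needed to hold the read-out at this one concentration. The single chloro left on the six-membered aromatic ring therefore suffices here, although this read-out shows only the size of the effect at the one concentration tested. No measurement available here accounts for this result. Still open, as far as these compounds go, is whether an unsubstituted phenyl, or an amine or methoxy group at this position, keeps the read-out. From the compounds shown here alone, a longer linking chain also remains open.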